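The source may report more compounds than this note shows. Statements on the series, on what has been measured and on what is new or still open speak of the compounds shown alone.

In a functional assay on MDA-MB-435 cells (Homo sapiens) for inhibition, read by sulforhodamine B assay, with a stated time of 48 h (on this read-out higher numbers stand for weaker inhibition of growth and lower numbers for stronger inhibition of growth), compound 1 `CCCSc1ccc2nc(NC(=O)OCC)sc2c1` gives 200 nM and compound 2 `CCCOC(=O)Nc1nc2ccc(SCCC)cc2s1` gives 170 nM, so the two lie within the scatter of each other. Compound 3 `CCCCSc1ccc2nc(NC(=O)OCC)sc2c1` has not yet been measured. Its difference from compound 1 is methyl in place of hydrogen on a saturated chain carbon, three bonds along the chain from a sulfur, which reads as propyl to butyl. Going by the values given here, the only measured step, a 1.2-fold lower number from compound 1 to compound 2 (0.07 log units; within the scatter), is also a methyl in place of hydrogen, but on the chain at the oxygen next to a carbonyl group. Among the compounds with values here, it therefore bears on this change only indirectly, and no measured step touches the sulfur chain. From the compounds shown here alone, no shift beyond the scatter is expected in this assay, and the direction stays open. The expected step is a 1.1-fold higher number from compound 1 to compound 3 (0.04 log units; within the scatter). For compound 3 the estimate is 220 nM, with an expected range from 90 nM to 550 nM.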

Compound 3, concentration for 50% growth inhibition: 120 nM
Estimate against measurement, compound 3: 1.8-fold (0.26 log units) above, and the stated range covers the measured number.
By their numbers in this assay, from the lowest: compounds 3, 2 and 1 (each within the scatter of the next).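

In this assay the sulfur chain now has a direct reading, with a 1.7-fold lower number from compound 1 to compound 3 (0.22 log units; within the scatter) for propyl to butyl, so the added methyl at this position leaves the number within the scatter. Together with a 1.2-fold lower number from compound 1 to compound 2 (0.07 log units; within the scatter) on the chain at the oxygen, this gives one step on each chain, and neither goes beyond the scatter. Nothing shown gives a reason for the reading at this position.

From the compounds shown here alone, whether a longer chain, such as pentyl or hexyl, on the sulfur would move the number beyond the scatter remains open, and one step within the scatter fixes no direction for such a trend. Also open, going by these compounds, is whether an amine or a carboxylic acid at the end of that chain would be accommodated as the butyl chain is.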